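The source may report more compounds than this note shows. Statements on the series, on what has been measured and on what is new or still open speak of the compounds shown alone.

Measured compounds:
compound 1 `CN(C)C(=O)c1cc2cnc(Nc3ccc(S(=O)(=O)NCCCN=C=S)cc3)nc2n1C1CCCC1` — 102%
compound 2 `CN(C)C(=O)c1cc2cnc(Nc3ccc(C(=O)NCCCCCCCN=C=S)cc3F)nc2n1C1CCCC1` — 12.7%
compound 3 `CN(C)C(=O)c1cc2cnc(Nc3ccc(C(=O)NCCCCN=C=S)cc3O)nc2n1C1CCCC1` — 41.7%

In a functional assay on A549 cells (Homo sapiens) for inhibition, read by CCK-8 assay, with a stated time of 72 h, tested at 10 uM (on this read-out higher numbers stand for a stronger effect at the one concentration tested and lower numbers for a weaker effect), compound 1 gives 102% and stands highest of the three numbers. The nearest value is that of compound 3 at 41.7%, a gap beyond the scatter; the furthest is compound 2 at 12.7%, also well beyond the scatter. Among the compounds with values here, no two measured compounds differ in only one place, so no single-change step can serve as a direct guide.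

Compound 4 `CN(C)C(=O)c1cc2cnc(Nc3ccc(NC(=O)CCCCCCN=C=S)cc3)nc2n1C1CCCC1` is not yet measured. It differs from compound 1 in one place: a group of 12 heavy atoms (8 carbon, 2 nitrogen, 1 oxygen, 1 sulfur; no ring) in place of a group of 10 heavy atoms (4 carbon, 2 nitrogen, 2 oxygen, 2 sulfur; no ring), on an aromatic carbon. Within the data shown here, both measured compounds that carry a group other than the one in compound 1 on that aromatic carbon sit far lower, though each also differs from compound 1 elsewhere on that ring, so the comparison is loose. A downward step from compound 1 to compound 4 is therefore expected, likely beyond the scatter, estimated at a number 57 percentage points lower from compound 1 to compound 4 (beyond the scatter). Compound 4 is expected to give about 45% in this assay, within a range of 15% to 85%.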

Compound 4, a percentage reported as inhibition, at one concentration (the size of the read-out at that concentration, not a potency): 102%
Estimate against measurement, compound 4: 57 percentage points below; the whole stated range lies below it.
By their numbers in this assay, from the lowest: compound 2; then compound 3; then compounds 1 and 4 (each within the scatter of the next).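

Within the data shown here, the first single-change step, on an aromatic carbon para to a large group, reads no change at the digits printed from compound 1 to compound 4 (within the scatter) in this assay. Among these compounds, at this position, the group of 12 heavy atoms therefore stands in for the group of 10 heavy atoms with no visible loss at the one concentration tested, which no earlier pair could show. Nothing at hand accounts for this flat step.

From the compounds shown here alone, whether the same position also tolerates a carboxylic acid, a simple amine or a longer chain remains open. With compound 1 and compound 4 read at a single concentration, any difference in potency between them also remains unresolved.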